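The compounds below may be only part of what the source reports. "The series", "measured", "known", "first", "only" and "open" are said of these compounds alone.

Compound 1 (`COc1ccc(CNc2cc(OC)c(OC)c(OC)c2)cc1Cl`) gives 46200 nM in a functional assay on MGC-803 cells (Homo sapiens) for inhibition, read by MTT assay, with a stated time of 48 h; on this read-out lower numbers stand for stronger inhibition and higher numbers for weaker inhibition. Compound 2 (`C/C=C/C(=O)N(Cc1ccc(OC)c(N)c1)c1cc(OC)c(OC)c(OC)c1`) gives 150 nM in this assay. Compound 1 therefore holds the higher of the two numbers, which means the weaker inhibition, and the gap between them lies beyond the usual scatter of repeated measurements. Among the measured compounds shown here, no two measured compounds differ in just one place, so the data do not show what any single change does.

Compound 3 (`COc1ccc(CNc2cc(OC)c(OC)c(OC)c2)cc1C`) has not yet been measured. It keeps the core of compound 1 and changes one group: methyl in place of chloro on an aromatic carbon. This puts methyl in place of chloro on an aromatic carbon, ortho to a methoxy group. For the measured compounds named here, no measured pair shows this swap, so the expectation is cautious: no step beyond the scatter in this assay, and no firm direction. The expected 1.2-fold lower number from compound 1 to compound 3 (0.06 log units; within the scatter) is small, and the starting point is compound 1 at 46200 nM. For compound 3 the estimated value is 40000 nM, with an expected range of 12000 nM to 120000 nM.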

Compound 3, half-maximal inhibitory concentration: 56800 nM
Compound 3: the middle estimate sits 1.4-fold (0.15 log units) below what was measured; the measured number falls inside the stated range.
By their numbers in this assay, from the lowest: compound 2; then compounds 1 and 3 (each within the scatter of the next).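

In this assay, among the compounds shown here, putting methyl in place of chloro on this aromatic carbon, ortho to a methoxy group, gives a 1.2-fold higher number from compound 1 to compound 3 (0.09 log units; within the scatter), so the swap produces no step that can be told apart from the ordinary spread of repeated measurements. For the compounds shown here, this is the first direct reading at this position, and it shows that, on the core of compound 1, chloro and methyl cannot be separated by this read-out. No supporting measurement bears on why the two groups read alike, so no reason can be offered for it.

On these data alone, a single swap says little about the position as a whole, and it remains open whether another group on this same carbon, such as hydroxyl, nitrile or trifluoromethyl, would produce a step beyond the scatter. As far as these compounds go, it also remains open whether methyl and chloro would still read alike on a core carrying other changes, since this pair tests the swap in only one setting.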